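The compounds below may be only part of what the source reports. "The series", "measured", "known", "first", "only" and "open" are said of these compounds alone.

Compounds measured in an ADME assay on A549 cells (Homo sapiens) for cytotoxicity, read by resazurin assay, with a stated time of 48 h; a higher number here means that more compound is tolerated, a lower number that less compound is tolerated:

Compound 1, `O=C(Nc1ccc(NCC2CCCC2)cc1Cl)c1cc(Cl)ccc1O`: 21500 nM
Compound 2, `CC1(Nc2ccc(NC(=O)c3cc(Cl)ccc3O)c(Cl)c2)CCCC1`: 157000 nM
Compound 3, `O=C(Nc1ccc(NCc2ccccc2)cc1Cl)c1cc(Cl)ccc1O`: 19700 nM

Compound 3 gives the lowest of the three numbers, although compound 1 sits within the scatter of it, as a 1.1-fold lower number from compound 1 to compound 3 (0.04 log units; within the scatter) shows; only compound 2 stands clearly apart, with an 8.0-fold lower number from compound 2 to compound 3 (0.90 log units; beyond the scatter) and a 7.3-fold higher number from compound 1 to compound 2 (0.86 log units; beyond the scatter) marking the two steps that lie beyond the scatter. Compound 4, `O=C(Nc1ccc(NCc2cc(F)cc(Cl)c2)cc1Cl)c1cc(Cl)ccc1O`, has not yet been measured in this assay. It differs from compound 3 in one place: 3-chloro-5-fluorophenyl in place of phenyl on a saturated chain carbon bound to a nitrogen on an aromatic ring. Of the measured steps, only the change on the same saturated chain carbon bears on this one, and that step, a 1.1-fold lower number from compound 1 to compound 3 (0.04 log units; within the scatter), stayed within the scatter when phenyl replaced cyclopentyl; the large steps concern a different site. Nothing measured speaks to a chloro and a fluoro substituent on that phenyl. He therefore expects for compound 4 a step of about a 1.4-fold lower number from compound 3 to compound 4 (0.15 log units; within the scatter), a small move toward a lower number that may well remain within the scatter, and estimates a value of 14000 nM, between 6000 nM and 35000 nM.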

Compound 4, half-maximal cytotoxic concentration: 11100 nM
The estimate for compound 4 lay 1.3-fold (0.10 log units) above the measured number, within the range that was stated.
By their numbers in this assay, from the lowest: compounds 4, 3 and 1 (each within the scatter of the next); then compound 2.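

In this assay a phenyl carrying chloro and fluoro substituents on the saturated chain carbon bound to a nitrogen on an aromatic ring stays within the scatter of the plain phenyl (a 1.8-fold lower number from compound 3 to compound 4 (0.25 log units; within the scatter)) and of the cyclopentyl (a 1.9-fold lower number from compound 1 to compound 4 (0.29 log units; within the scatter)). For the compounds shown here, this position has therefore now taken cyclopentyl, phenyl and 3-chloro-5-fluorophenyl without a step beyond the scatter, while compound 2, with 1-methylcyclopentyl on the nitrogen, remains the one compound clearly apart, here by a large step (a 14-fold lower number from compound 2 to compound 4 (1.15 log units; beyond the scatter)). Nothing measured gives a reason for either result.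

From the compounds shown here alone, it remains open whether a phenyl with chloro alone or fluoro alone would read like the one carrying both. Going by these compounds, it is also open whether an amine or a carboxylic acid on that ring would stay within the scatter.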